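A few compounds are considered here, and "the series" means these few. Any claim that something is new, unique, unknown or untested is made for them only; others in the source may bear on it.

Measured so far in a functional assay on the whole organism (strain Swiss) for inhibition, with Mus musculus as the target, in the writhing test, with stated times of 30 min and 20 min, at a dose of 10 mg/kg by the intraperitoneal route; on this read-out lower numbers stand for less inhibition and higher numbers for more inhibition at the one dose given (going by the name of the read-out): compound 1 `Cc1c(N2C(=O)C(Cl)=C(Nc3cccc([N+](=O)[O-])c3)C2=O)c(=O)n(-c2ccccc2)n1C` gives 29.5%; compound 2 `Cc1c(N2C(=O)C(Cl)=C(Nc3ccc(Cl)c([N+](=O)[O-])c3)C2=O)c(=O)n(-c2ccccc2)n1C` gives 98.5%.

Compound 2 stands highest of the two numbers, its nearest neighbour being compound 1, with a step of a number 69 percentage points higher from compound 1 to compound 2 (beyond the scatter). Compound 3 `Cc1c(N2C(=O)C(Cl)=C(c3ccc[nH]3)C2=O)c(=O)n(-c2ccccc2)n1C` differs from compound 2 by 1H-pyrrol-2-yl in place of (4-chloro-3-nitrophenyl)amino on a double-bonded ring carbon. Among the compounds with values here, the only measured step concerns a chloro on the aromatic ring that now leaves entirely, so no step matches this change directly; that step was large, and its removal is expected to lower the value by a number 53.5 percentage points lower from compound 2 to compound 3 (beyond the scatter). Compound 3 is estimated at 45%, between 15% and 85%.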

Compound 3, a percentage reported as inhibition, in the whole organism at one dose (the size of the read-out at that dose, not a potency): 23.3%
Beside the measured number, compound 3's estimate is 21.7 percentage points above it, within the range that was stated.
By their numbers in this assay, from the lowest: compounds 3 and 1 (each within the scatter of the next); then compound 2.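

In this assay, replacing the whole group on the double-bonded ring carbon with 1H-pyrrol-2-yl has very different outcomes depending on the group it replaces: against (4-chloro-3-nitrophenyl)amino the change is a number 75.2 percentage points lower from compound 2 to compound 3 (beyond the scatter), while against (3-nitrophenyl)amino it is a number 6.2 percentage points lower from compound 1 to compound 3 (within the scatter), so only the first comparison shows a real loss. Of the three groups at this place, only (4-chloro-3-nitrophenyl)amino goes with a high number. Nothing given here explains either step.

Going by these compounds, it remains open whether (4-chlorophenyl)amino, which keeps the chloro and lacks the nitro group, would retain the high number. A saturated amine such as morpholine at this place is equally untested by these compounds.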